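Homologation of the ring-nitrogen alkyl chain in a sulfamoyl anilinopyrimidine

The source may report more compounds than this note shows. Statements on the series, on what has been measured and on what is new or still open speak of the compounds shown alone.

The measured compounds:
compound 1, `Cn1nc(-c2ccnc(Nc3cccc(O)c3)n2)c2ccccc21`, 17200 nM
compound 2, `CCn1nc(-c2ccnc(Nc3cccc(S(N)(=O)=O)c3)n2)c2ccccc21`, 9010 nM
compound 3, `CCn1nc(-c2ccnc(Nc3cccc(O)c3)n2)c2ccccc21`, 36600 nM

Of the compounds shown here, three sharing the same core have been tested in a functional assay on HCT-116 cells (Homo sapiens) for antiproliferative activity, read by MTT assay, with a stated time of 72 h; on this read-out higher numbers stand for weaker inhibition of growth and lower numbers for stronger inhibition of growth. Compound 2 has the lowest number of the three, and compound 1 sits within the scatter of it, so no order between those two can be claimed. Compound 3 stands apart: the step of a 4.1-fold higher number from compound 2 to compound 3 (0.61 log units; beyond the scatter) replaces hydroxy with sulfamoyl on an aromatic carbon and is beyond the scatter. The difference between the cores of compound 1 and compound 2 is not broken down here.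

Within the hydroxy series, the change methyl in place of hydrogen on a saturated chain carbon bound to an aromatic nitrogen gave the step of a 2.1-fold higher number from compound 1 to compound 3 (0.33 log units; beyond the scatter), a modest weakening. Compound 4, `CCCn1nc(-c2ccnc(Nc3cccc(S(N)(=O)=O)c3)n2)c2ccccc21`, has not yet been measured. It differs from compound 2 by methyl in place of hydrogen on a saturated chain carbon, two bonds along the chain from an aromatic nitrogen. This is the same kind of change, but not the same: in compound 3 the entering methyl sits on a saturated chain carbon bound to an aromatic nitrogen, whereas in compound 4 it sits two bonds along the chain from that nitrogen, so the chain grows from ethyl to propyl rather than from methyl to ethyl.

Because the earlier homologation gave a 2.1-fold higher number from compound 1 to compound 3 (0.33 log units; beyond the scatter), a step of similar size and direction is expected for compound 4 in this assay, namely a 1.9-fold higher number from compound 2 to compound 4 (0.28 log units; within the scatter). Compound 4 is therefore estimated at 17000 nM, with a plausible range from 7500 nM to 38000 nM.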

Compound 4, concentration for 50% growth inhibition: 7950 nM
The estimate for compound 4 lay 2.1-fold (0.33 log units) above the measured number; measured number inside the range.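

In this assay, lengthening the chain from ethyl to propyl in the sulfamoyl compounds gave a 1.1-fold lower number from compound 2 to compound 4 (0.05 log units; within the scatter), so compound 4 cannot be told apart from compound 2 on this read-out. Set beside the earlier step in the hydroxy compounds, this step does not differ from it by more than the scatter of two such steps allows: the same change on two cores in this assay, a 2.1-fold higher number (0.33 log units; beyond the scatter) from compound 1 to compound 3 and a 1.1-fold lower number (0.05 log units; within the scatter) from compound 2 to compound 4, 2.4-fold (0.38 log units) apart, within the scatter of two such steps. Within the data shown here, this gives no ground for saying that the change behaves differently from one core to the other, but it does not show that the change carries over unchanged; only one of the two steps lies beyond the scatter, the methyl enters at a different place along the chain in each, and the part played by the core cannot be separated from that of the chain length.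

The compounds shown leave open what the step from methyl to ethyl does in the sulfamoyl compounds and what the step from ethyl to propyl does in the hydroxy compounds, either of which would help to separate those two influences. They also leave open whether a longer chain such as butyl, or an amine or a carboxylic acid in place of the propyl chain, would move the number in this series.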